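The compounds below may be only part of what the source reports. "The series", "measured", "known", "first", "only" and "open" are said of these compounds alone.

Measured compounds:
Compound 1, `O=CN1CCN(c2ccc(Cl)cc2)C1=S`: 16400 nM
Compound 2, `N#C/C(=C\N1CCN(C(=O)c2ccco2)C1=S)C(N)=O`: 13100 nM
Compound 3, `O=CN1CCN(C(=O)c2ccco2)C1=S`: 15900 nM

All three were tested in a functional assay on MDA-MB-231 cells (Homo sapiens) for inhibition, read by sulforhodamine B assay, with a stated time of 48 h; a higher number here means a weaker inhibitor of growth, a lower number a stronger inhibitor of growth. The number for compound 2 differs from those of compound 3 and compound 1 by less than the usual scatter of this kind of measurement, so the three cannot be told apart on these data.

Compound 4, `N#C/C(=C\N1CCN(C(=O)c2ccco2)C1=S)C(=O)Nc1ccc(Cl)cc1`, has not yet been measured. It differs from compound 2 in one place: 4-chlorophenyl in place of hydrogen on an amide-type nitrogen. For the measured compounds named here, no measured pair shows what this change does in this assay, so its effect cannot be read from the data. The step expected here, a 1.6-fold lower number from compound 2 to compound 4 (0.21 log units; within the scatter), is a modest lowering, barely beyond the scatter. Compound 4 is therefore estimated at 8000 nM, within a range from 2500 nM to 25000 nM.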

Compound 4, concentration for 50% growth inhibition: 18400 nM
The estimate for compound 4 lay 2.3-fold (0.36 log units) below the measured number; the range from low to high includes it.
By their numbers in this assay, from the lowest: compounds 2, 3, 1 and 4 (each within the scatter of the next).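

In this assay, 4-chlorophenyl in place of hydrogen on the amide-type nitrogen gives a 1.4-fold higher number from compound 2 to compound 4 (0.15 log units; within the scatter), the first direct view of this position. Adding this six-membered aromatic ring therefore leaves the number indistinguishable from that of the parent, so the change has no detectable effect here. Nothing in the available data explains this result.

On these data alone, it remains open whether a different group on this nitrogen, such as methyl or a longer alkyl chain, would move the number beyond the scatter. The same question applies to a carboxylic acid in place of the chlorine.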